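The source may hold more compounds than are shown below. What is called first, only, known or untested is meant among the compounds shown, and "the series" means these compounds.

Compound 1 `Cn1c(Sc2c(F)cc(C(=O)NO)cc2F)nnc1-c1cccs1`: > 1000 nM
Compound 2 `Cn1c(Sc2c(F)cc(C(=O)NO)cc2F)nnc1-c1cccnn1`: > 1000 nM

In an ADME assay on PBMC cells (Homo sapiens) for cytotoxicity, with a stated time of 72 h (on this read-out higher numbers stand for weaker inhibition and lower numbers for stronger inhibition), compound 2 gives > 1000 nM, which is a limit of the assay and not a number. In this assay compound 1 gives > 1000 nM, again a limit. The evidence so far is therefore (the limit of > 1000 nM in this assay, at which 2 of the 2 values shown sit).

Compound 3 `Cn1c(Sc2c(F)cc(C(=O)NO)cc2F)nnc1-c1ncccc1F` keeps the core of compound 2 and differs in one place, with 3-fluoropyridin-2-yl in place of pyridazin-3-yl on an aromatic carbon. Among the measured compounds shown here, the one measured step that bears on this is an exchange at the same place, a step that the two limits leave unreadable from compound 1 to compound 2. Its size cannot be read, so it offers no size to carry over. No step beyond the scatter is expected in this assay. The expected step is a step that the limit leaves unreadable from compound 2 to compound 3. Compound 3 is estimated at 1500 nM, with an expected range from 800 nM to 5000 nM, and it will most likely be reported as a limit again.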

Compound 3, half-maximal inhibitory concentration: > 1000 nM
Compound 3 was reported as a limit (the forecaster's own chance of this, stated with the estimate: 85%); the middle value is on the limit's open side.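

In this assay compound 3 gives > 1000 nM, a limit of the assay. The steps from compound 1 and from compound 2 to compound 3 cannot be read: the limit of > 1000 nM in this assay, at which 3 of the 3 values shown sit. The compounds shown leave open whether these three differ at all in this assay.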